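Swapping Chlorine for Fluorine on the Ester Ring

The source may hold more compounds than are shown below. What is called first, only, known or untested is meant among the compounds shown, and "the series" means these compounds.

In an ADME assay on cells (T-cell, Mus musculus, strain BALB/c) for cytotoxicity, read by MTT assay, with a stated time of 48 h (a lower number here means that less compound is tolerated, a higher number that more compound is tolerated), compound 1 `COC(=O)c1c(Br)cc(Br)cc1OC(=O)COc1cc(O)c2c(=O)cc(-c3ccccc3)oc2c1` gives 398000 nM, compound 2 `COC(=O)c1c(Cl)cc(Cl)cc1OC(=O)COc1cc(O)c2c(=O)cc(-c3ccccc3)oc2c1` gives 345000 nM and compound 3 `COC(=O)c1ccc(Cl)cc1OC(=O)COc1cc(O)c2c(=O)cc(-c3ccccc3)oc2c1` gives 265000 nM. Compound 3 stands lowest of the three values, but its gaps to compound 2 and to compound 1 are both within the scatter, so the three compounds cannot be told apart in this assay. Compound 4 `COC(=O)c1cc(F)ccc1OC(=O)COc1cc(O)c2c(=O)cc(-c3ccccc3)oc2c1` has not yet been measured. It differs from compound 3 by a group of 11 heavy atoms (8 carbon, 2 oxygen, 1 fluorine; one six-membered aromatic ring of carbon only) in place of a group of 11 heavy atoms (8 carbon, 2 oxygen, 1 chlorine; one six-membered aromatic ring of carbon only), on an oxygen next to a carbonyl group. Among the measured compounds shown here, the only measured step that bears on this change, a 1.3-fold lower number from compound 2 to compound 3 (0.11 log units; within the scatter), is itself within the scatter, and it involved removing a halogen rather than exchanging one. With every gap in the set inside the scatter, the step from compound 3 to compound 4 is expected to be a 1.1-fold higher number from compound 3 to compound 4 (0.02 log units; within the scatter), meaning no change that can be told from repeat measurement. Compound 4 is therefore estimated to give 280000 nM in this assay, with a range from 150000 nM to 520000 nM.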

Compound 4, half-maximal cytotoxic concentration: 389000 nM
Compound 4: the middle estimate sits 1.4-fold (0.14 log units) below what was measured; measured number inside the range.
By their numbers in this assay, from the lowest: compounds 3, 2, 4 and 1 (each within the scatter of the next).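

Exchanging the 5-chloro-2-(methoxycarbonyl)phenyl group for its fluorine-bearing counterpart, on an oxygen next to a carbonyl group, gives a 1.5-fold higher number from compound 3 to compound 4 (0.17 log units; within the scatter) in this assay and so cannot be told from repeat measurement. The earlier step only took a chloro group away, whereas this one exchanges one halogen-bearing group for another, and here too the number stays within the scatter. Nothing measured here offers an explanation for this result.

The compounds shown leave open whether a group of a different kind on this ring, such as an amine or a carboxylic acid, would give a step beyond the scatter. They also leave open what a longer chain in place of the methyl of the methoxycarbonyl group would do in this assay.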